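The source may hold more compounds than are shown below. What is called first, only, known or untested is meant among the compounds shown, and "the series" means these compounds.

In a toxicity assay on HeLa cells (Homo sapiens) for cytotoxicity, read by MTT assay, with a stated time of 24 h (on this read-out lower numbers stand for stronger inhibition and higher numbers for weaker inhibition), compound 3 `CCN1CCN(CC(O)Cn2c([N+](=O)[O-])cnc2C)CC1` gives 4940000 nM, the highest of the three numbers in hand. Compound 1 `Cc1ncc([N+](=O)[O-])n1CC(O)CSC(=S)N1CCCCCC1` gives 411000 nM and compound 2 `Cc1ncc([N+](=O)[O-])n1CC(O)CSC(=S)N1CCN(C(=O)OC(C)(C)C)CC1` gives 689000 nM; both sit well below compound 3, and these two differ from it in several places at once, so no single step can be read off. Compound 4 `Cc1ncc([N+](=O)[O-])n1CC(O)CN1CCN(c2ccco2)CC1` differs from compound 3 in one place: furan-2-yl in place of ethyl on an amine nitrogen in a ring. Among the measured compounds shown here, with no measured step of this kind to lean on, a modest move toward a lower number in this assay is expected, though it may not clear the usual scatter. The estimate from compound 3 to compound 4 is a 2.5-fold lower number from compound 3 to compound 4 (0.39 log units; beyond the scatter). For compound 4 the expected value is 2000000 nM, within a range of 600000 nM to 6000000 nM.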

Compound 4, half-maximal inhibitory concentration: 3520000 nM
For compound 4 the middle estimate is 1.8-fold (0.25 log units) below the measured one; the measured number falls inside the stated range.
By their numbers in this assay, from the lowest: compounds 1 and 2 (each within the scatter of the next); then compounds 4 and 3 (each within the scatter of the next).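

In this assay, furan-2-yl in place of ethyl on the amine nitrogen in the ring gives a 1.4-fold lower number from compound 3 to compound 4 (0.15 log units; within the scatter). Among the compounds shown here, this is the first comparison here that differs in one place, and it shows that this nitrogen can carry the larger aromatic ring with no difference that can be told from the scatter. Nothing measured here explains this result. From the compounds shown here alone, whether a phenyl ring, a carboxylic acid or a longer chain on this nitrogen would shift the number beyond the scatter stays open. So does whether furan-2-yl would give the same result on a different core.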